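Swapping a hydroxyphenyl arm on a shared pyridine core

The source may report more compounds than this note shows. Statements on the series, on what has been measured and on what is new or still open speak of the compounds shown alone.

Of the compounds shown here, three have been measured. Compound 1 `Oc1cccc(-c2cc(-c3ccc(OC(F)(F)F)cc3)cc(-c3ccccc3O)n2)c1` gives 9410 nM in a functional assay on HCT-15 cells (Homo sapiens) for inhibition; a higher number here means a weaker inhibitor, a lower number a stronger inhibitor. Compound 2 `Oc1ccc(-c2cc(-c3ccc(OC(F)(F)F)cc3)cc(-c3ccccc3O)n2)cc1` sits at a limit of this assay, > 50000 nM, rather than at a number. Compound 3 `Oc1ccc(-c2cc(-c3cccc(OC(F)(F)F)c3)cc(-c3cccc(O)c3)n2)cc1` gives 1730 nM in this assay, the lower of the two numbers, and the difference between its core and the core of compound 1 is not broken down here.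

Within the data shown here, the one measured change is 4-hydroxyphenyl in place of 3-hydroxyphenyl on an aromatic carbon, which produced an at least 5.3-fold higher number from compound 1 to compound 2 (0.72 log units; beyond the scatter); the size of that step is known only as a bound because of the limit of > 50000 nM in this assay, at which 1 of the 3 values shown sits. The same kind of change is now made from compound 3 to compound 4 `Oc1ccc(-c2cc(-c3cccc(OC(F)(F)F)c3)cc(-c3ccc(O)cc3)n2)cc1`, namely (4-hydroxyphenyl in place of 3-hydroxyphenyl on an aromatic carbon). It differs from the earlier one in its surroundings: in compound 1 the position is meta to a 2-hydroxyphenyl group, in compound 3 meta to a 4-hydroxyphenyl group. Resting on compound 3 and its value 1730 nM and on the weakening seen from compound 1 to compound 2, compound 4 is expected to show a 5.2-fold higher number from compound 3 to compound 4 (0.72 log units; beyond the scatter) in this assay. Compound 4 is estimated at 9000 nM, with a likely span from 3000 nM to 40000 nM.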

Compound 4, half-maximal inhibitory concentration: > 50000 nM
Compound 4 gave a limit, no number; the forecaster's own chance of this, stated with the estimate: 15%; middle value at least 5.5-fold (0.74 log units) away from the limit.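

In this assay compound 4 sits at > 50000 nM, which is a limit and not a number. Putting 4-hydroxyphenyl in place of 3-hydroxyphenyl gave an at least 28-fold higher number from compound 3 to compound 4 (1.46 log units; beyond the scatter), so on both cores shown the change moved the number the same way, and in each case beyond the scatter. This shows that the direction carried over from one core to the other, but it does not show that the size of the step carried over or that the surroundings changed it, as both steps are known only as bounds: the same change on two cores in this assay, an at least 5.3-fold higher number (0.72 log units; beyond the scatter) from compound 1 to compound 2 and an at least 28-fold higher number (1.46 log units; beyond the scatter) from compound 3 to compound 4; the limit leaves it open whether they differ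

The compounds shown leave open how far compound 2 and compound 4 really lie from their partners, and whether the same change would go the same way on any core beyond these two. They also leave open how an amine or a carboxylic acid in place of the hydroxy group on this arm would read in this assay.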